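Inverting one stereocentre of compound 3

A few compounds are considered here, and "the series" means these few. Any claim that something is new, unique, unknown or untested is made for them only; others in the source may bear on it.

In a functional assay on A549 cells (Homo sapiens) for cytotoxicity, read by MTT assay, with a stated time of 48 h (on this read-out higher numbers stand for weaker inhibition and lower numbers for stronger inhibition), compound 3 (`CCOC(=O)[C@]1(C(=O)Nc2ccccc2Cl)C[C@H]1c1cc(OC)c(OC)c(OC)c1`) gives 13400 nM and its mirror image, compound 2 (`CCOC(=O)[C@@]1(C(=O)Nc2ccccc2Cl)C[C@@H]1c1cc(OC)c(OC)c(OC)c1`), gives 29000 nM on the same read-out. Compound 1 (`CCOC(=O)C1(C(=O)Nc2ccccc2Cl)CC1c1cc(OC)c(OC)c(OC)c1`), drawn without defined configuration, gives 18000 nM; 18500 nM (2 entries) in its entries. Compound 3 thus holds the lower number of the mirror-image pair. For the measured compounds named here, the only measured step, a 2.2-fold lower number from compound 2 to compound 3 (0.34 log units; beyond the scatter) (modest), inverts both stereocentres.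

Compound 4 (`CCOC(=O)[C@@]1(C(=O)Nc2ccccc2Cl)C[C@H]1c1cc(OC)c(OC)c(OC)c1`) brings this change: the two compounds have the same atoms and bonds and differ only in configuration as drawn: 1 of 2 stereo elements differ; a stereocentre at a saturated ring carbon is drawn R in compound 3 and S in compound 4 with a stereocentre at a saturated ring carbon drawn R in compound 3 and S in compound 4. Going by the values given here, no measured step inverts a single stereocentre. Resting on that modest step alone, a 1.5-fold higher number from compound 3 to compound 4 (0.17 log units; within the scatter) is expected, leaning toward a higher number. Compound 4 is estimated at 20000 nM (expected range 8000 nM to 45000 nM).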

Compound 4, half-maximal inhibitory concentration: 17600 nM
The estimate for compound 4 lay 1.1-fold (0.06 log units) above the measured number; the measured number falls inside the stated range.
By their numbers in this assay, from the lowest: compounds 3, 4 and 2 (each within the scatter of the next, the first and the last beyond it).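

Read in this assay, inverting a single stereocentre stays within the scatter at either centre (a 1.3-fold higher number from compound 3 to compound 4 (0.12 log units; within the scatter)) and (a 1.6-fold lower number from compound 2 to compound 4 (0.22 log units; within the scatter)). Only the double inversion, which links the mirror images compound 2 and compound 3, goes beyond the scatter, so compound 4 cannot be told apart from either of them. Configuration at one centre alone therefore gives no readable change in this series.

Going by these compounds, whether either stereocentre alone matters more in a related compound remains open. A carboxylic acid in place of the ethyl ester, or an amine on the aryl ring, could test this.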